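A few compounds are considered here, and "the series" means these few. Any claim that something is new, unique, unknown or untested is made for them only; others in the source may bear on it.

Working notes on the series. Going by the values given here, compound 1 `N[C@@H](CC(=O)OC[C@H]1O[C@@H](n2cc(F)c(=O)[nH]c2=O)C[C@@H]1O)C(=O)O` is an ester of the shared core, and in an assay on cells (Oocyte) for inhibition of sodium- and chloride-dependent neutral and basic amino acid transporter B(0+) (Homo sapiens), read by LC-MS, with a stated time of 10 min (a higher number here means a weaker inhibitor, a lower number a stronger inhibitor), compound 1 gives 820000 nM, the lowest of the two numbers so far. Compound 2 `N[C@@H](CCC(=O)O[C@H]1C[C@H](n2cc(F)c(=O)[nH]c2=O)O[C@@H]1CO)C(=O)O` in this assay gives 1840000 nM, a gap beyond the scatter. Among the compounds with values here, no single-change steps between measured compounds are available. Compound 3 `CC(C)[C@H](N)C(=O)OC[C@H]1O[C@@H](n2cc(F)c(=O)[nH]c2=O)C[C@@H]1O` differs from compound 1 as 1-amino-2-methylpropyl in place of 2-amino-2-carboxyethyl on a carbonyl carbon. The expected step of a 1.6-fold lower number from compound 1 to compound 3 (0.21 log units; within the scatter) is a small shift toward a stronger inhibitor, not clearly beyond the scatter. For compound 3 in this assay the estimate is 500000 nM, within 150000 nM to 1500000 nM.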

Compound 3, half-maximal inhibitory concentration: 980000 nM
Compound 3: middle estimate off by 2.0-fold (0.29 log units), on the low side; the measured number falls inside the stated range.
By their numbers in this assay, from the lowest: compounds 1, 3 and 2 (each within the scatter of the next, the first and the last beyond it).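

In this assay the exchange of 2-amino-2-carboxyethyl for 1-amino-2-methylpropyl on a carbonyl carbon stays within the scatter (a 1.2-fold higher number from compound 1 to compound 3 (0.08 log units; within the scatter)). At this position the two groups cannot be told apart, so the carboxylic acid of 2-amino-2-carboxyethyl is not required for a number of this size. No measurement on hand bears on the reason for this result.

Open, from the compounds shown here alone, is whether a longer chain or a phenyl group on this carbonyl carbon would move the number beyond the scatter from compound 1.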